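Acid dissociation notes: furan-2-yl replaces hydroxy-methoxyphenyl

The source may hold more compounds than are shown below. What is called first, only, known or untested is meant among the compounds shown, and "the series" means these compounds.

Measured compounds:
compound 1 `CC(C)(C)c1ccc(Oc2ccc3c(NCCCNCc4ccco4)ccnc3c2)cc1` gives 9.28
compound 2 `COc1ccc(Oc2ccc3c(NCCCNCc4ccco4)ccnc3c2)cc1` gives 9.28
compound 3 `COc1cccc(CNCCCNc2ccnc3cc(Oc4cccc(N(C)C)c4)ccc23)c1O` gives 9.28

All three values come from a physicochemical assay for acid dissociation. Compound 3 stands level with compounds 1 and 2 at the digits shown; its nearest neighbour is compound 1 and its furthest compound 2, both without change beyond the scatter. Going by the values given here, the one measured step, no change at the digits printed from compound 1 to compound 2 (within the scatter), concerns a substituent on an aromatic carbon and left the read-out unchanged.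

Compound 4 `CN(C)c1cccc(Oc2ccc3c(NCCCNCc4ccco4)ccnc3c2)c1` is the next to be measured in this assay. It differs from compound 3 by furan-2-yl in place of 2-hydroxy-3-methoxyphenyl on a saturated chain carbon bound to an amine nitrogen. Among the compounds with values here, no measured step touches this position, so the comparison rests on the fact that compounds 1 and 2, which already carry the ((furan-2-yl)methyl)amino group, give the same value as compound 3, which does not. On that basis the step of no change at the digits printed from compound 3 to compound 4 (within the scatter) is expected to lie within the scatter. Compound 4 is therefore estimated at 9.28, with a range from 8.9 to 9.7.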

Compound 4, acid dissociation constant: 9.28
Compound 4: the middle estimate sits on the measured number at the digits printed; the range from low to high includes it.
By their numbers in this assay, from the lowest: compounds 1, 2, 3 and 4 (each within the scatter of the next).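

In this assay, the change on a saturated chain carbon bound to an amine nitrogen now has a direct reading: no change at the digits printed from compound 3 to compound 4 (within the scatter), with furan-2-yl in place of 2-hydroxy-3-methoxyphenyl. The group on an oxygen on an aromatic ring now has two readings of its own, no change at the digits printed from compound 2 to compound 4 (within the scatter) for 3-(dimethylamino)phenyl in place of 4-methoxyphenyl and no change at the digits printed from compound 1 to compound 4 (within the scatter) for 3-(dimethylamino)phenyl in place of 4-(tert-butyl)phenyl. No supporting measurement accompanies these results, and nothing can be said of what underlies them.

As far as these compounds go, whether the read-out would stay level with an aliphatic amine or a carboxylic acid in place of furan-2-yl remains open. The compounds shown also leave open which proton in these structures the read-out follows.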